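The compounds below may be only part of what the source reports. "The series", "measured", "known", "first", "only" and "open" are said of these compounds alone.

Measured so far in an in vivo ADME assay on the whole organism (plasma) for pharmacokinetics, with Rattus norvegicus as the target; on this read-out higher numbers stand for fast clearance and lower numbers for slow clearance:

- Compound 1 `CC(C)NC(=O)[C@H]1CC[C@@H](n2/c(=N/C(=O)c3ccc(F)cc3)[nH]c3ccc(CN4CCC[C@H]4C(C)(C)O)cc32)CC1`: "not determined" (no result reported)
- Compound 2 `CC(C)NC(=O)[C@H]1CC[C@@H](n2/c(=N/C(=O)c3ccc(F)cc3)[nH]c3ccc(CN4CCCCC4)cc32)CC1`: "not determined" (no result reported)
- Compound 3 `CC(C)NC(=O)[C@H]1CC[C@@H](n2/c(=N/C(=O)c3ccc(F)cc3)[nH]c3ccc(CN4CCNC(=O)C4)cc32)CC1`: 180 mL/min/kg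

Of these three compounds, only compound 3 has a number, 180 mL/min/kg. It therefore stands alone, with nothing to rank it against, since neither compound 1 nor compound 2 gave a result.

The next compound to be tested in this assay is compound 4 `CC(C)NC(=O)[C@H]1CC[C@@H](n2/c(=N/C(=O)c3ccc(F)cc3)[nH]c3ccc(CNCC(C)(C)O)cc32)CC1`. It departs from compound 3 at one place, where (2-hydroxy-2-methylpropyl)amino takes the position of 3-oxopiperazin-1-yl on a saturated chain carbon bound to an aromatic carbon: (2-hydroxy-2-methylpropyl)amino in place of 3-oxopiperazin-1-yl on a saturated chain carbon bound to an aromatic carbon. The ring is thus replaced by an open chain, and the rest of the molecule stays the same.

Going by the values given here, no measured pair of compounds shows what such a change does, so the data offer no direct guide to the size of the step. The expectation rests on compound 3 alone, whose 180 mL/min/kg is taken to leave more room downward than upward. A moderate fall is expected, stated as the estimated 2.3-fold lower number from compound 3 to compound 4 (0.35 log units; beyond the scatter), although no change beyond the scatter remains possible. The estimate for compound 4 is 80 mL/min/kg, with an expected range from 30 mL/min/kg to 180 mL/min/kg.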

Compound 4, clearance: 21.7 mL/min/kg
The estimate for compound 4 lay 3.7-fold (0.57 log units) above the measured number; measured number outside the range, below it.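

Going by these compounds alone, this is the first measured pair at this place. In this assay it shows that the read-out responds to the group on a saturated chain carbon bound to an aromatic carbon: (2-hydroxy-2-methylpropyl)amino in place of 3-oxopiperazin-1-yl gives an 8.3-fold lower number from compound 3 to compound 4 (0.92 log units; beyond the scatter). With the rest of the molecule unchanged, this move toward slower clearance belongs to a single exchange, in which a six-membered non-aromatic ring leaves and an open chain with no ring enters. No measurement at hand bears on why the number fell.

Within the data shown here, the steps to compound 1 and compound 2 cannot be read, as neither has a number, so the single pair cannot separate the loss of the ring from the arrival of the hydroxyl-bearing chain. On these data alone, it also remains open whether a (2-methylpropyl)amino group without the hydroxyl, a longer chain on the amine, or a carboxylic acid at this place would give a number closer to that of compound 3 or to that of compound 4.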